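This account rests on a few compounds, and the source may have more. Where it says the series, first, only, none or still open, it means among the compounds named here.

Of the compounds shown here, two on the shared core have been read in an ADME assay on microsomes from liver (Homo sapiens) for metabolic stability, with a stated time of 10 min, tested at 0.5 uM; a higher number here means that more of the compound is left, a lower number that less of the compound is left. There, compound 1 `C[C@@H](NCc1ccc(Cl)cc1)[C@H]1CC[C@@H](c2ccnc3ccc(F)cc32)CC1` gives 34%, and compound 2 `C[C@@H](NC(=O)C12CCC(Cl)(CC1)CC2)[C@H]1CC[C@@H](c2ccnc3ccc(F)cc32)CC1` gives 9%, the lower of the two numbers, with a gap beyond the scatter. Compound 3 `C[C@@H](NC(=O)C1CCCCC1)[C@H]1CC[C@@H](c2ccnc3ccc(F)cc32)CC1` has not yet been measured. It keeps the rest of compound 2 and differs only on the carbonyl carbon: a group of 6 heavy atoms (6 carbon; one six-membered non-aromatic ring of carbon only) in place of a group of 9 heavy atoms (8 carbon, 1 chlorine; 2 six-membered non-aromatic rings of carbon only), on a carbonyl carbon. Among the compounds with values here, no measured pair isolates this change, so the expectation rests on the low starting point of compound 2 at 9% and on the amide being retained. Only a small rise, within the scatter, is expected in this assay: the expected step is a number 3 percentage points higher from compound 2 to compound 3 (within the scatter). For compound 3 the estimated value is 12%, with an expected range from 3% to 32%.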

Compound 3, percent of the compound remaining: 6%
For compound 3 the middle estimate is 6 percentage points above the measured one; the range from low to high includes it.
By their numbers in this assay, from the lowest: compounds 3 and 2 (each within the scatter of the next); then compound 1.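

In this assay, cyclohexyl in place of the group of 9 heavy atoms on a carbonyl carbon gives a number 3 percentage points lower from compound 2 to compound 3 (within the scatter), so the chlorine and the second ring of compound 2 show no readable effect at this position. Cyclohexylcarbonyl in place of 4-chlorobenzyl on an amine nitrogen gives a number 28 percentage points lower from compound 1 to compound 3 (beyond the scatter), so the gap already seen with compound 2 also holds for the amide with the smaller group, and both amides stand apart from the amine compound 1. Nothing at hand explains this difference.

Still open, going by these compounds, is whether the gap follows the carbonyl or the group it carries, which a cyclohexylmethyl group on the amine nitrogen would separate. Also open, on these data alone, is whether a hydroxyl on the cyclohexyl ring would lift the number for the amide.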